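The source may report more compounds than this note shows. Statements on the series, on what has been measured and on what is new or still open speak of the compounds shown alone.

Measured so far in a functional assay on OCI-Ly3 cells (Homo sapiens) for inhibition, read by CellTiter-Glo, with stated times of 48 h and 96 h; on this read-out higher numbers stand for weaker inhibition of growth and lower numbers for stronger inhibition of growth:
Compound 1 `CC(C)[C@H](NC(=O)c1ccccc1Br)C(=O)N1CCC[C@H]1C(=O)N[C@@H](CCCNC(=N)N)C(=O)CF`: 4240 nM
Compound 2 `CC(C)[C@H](NC(=O)c1ccc(Cl)cc1)C(=O)N1CCC[C@H]1C(=O)N[C@@H](CCCNC(=N)N)C(=O)CF`: 1240 nM
Compound 3 `CC(C)[C@H](NC(=O)OCc1ccccc1)C(=O)N1CCCC[C@H]1C(=O)N[C@@H](CCCNC(=N)N)C(=O)CF`: 730 nM

Compound 3, at 730 nM, lies within the usual scatter of compound 2 and clearly below compound 1. The next molecule, compound 4 `CC(C)[C@H](NC(=O)c1ccc(Br)cc1)C(=O)N1CCCC[C@H]1C(=O)N[C@@H](CCCNC(=N)N)C(=O)CF`, differs from compound 3 in one place: 4-bromophenyl in place of benzyloxy on a carbonyl carbon. Put simply, 4-bromophenyl stands in place of benzyloxy on a carbonyl carbon.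

Among the measured compounds shown here, no measured step shows this exact swap. For the measured compounds named here, the only step available is a 3.4-fold lower number from compound 1 to compound 2 (0.53 log units; beyond the scatter), a modest change that comes with 4-chlorophenyl in place of 2-bromophenyl on a carbonyl carbon. It shows that a change at this kind of place can move the number beyond the scatter, but it says little about replacing benzyloxy. The closest comparison is compound 2, which has 4-chlorophenyl on the carbonyl carbon and gives 1240 nM, although it also differs from compound 4 elsewhere. That value points to a slightly higher number than that of compound 3, but not to a step clearly beyond the scatter. The expected change is a 1.4-fold higher number from compound 3 to compound 4 (0.14 log units; within the scatter). For compound 4, the estimated value in this assay is 1000 nM, with an expected range of 400 nM to 2500 nM.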

Compound 4, concentration for 50% growth inhibition: 460 nM
For compound 4 the middle estimate is 2.2-fold (0.34 log units) above the measured one; the measured number falls inside the stated range.
By their numbers in this assay, from the lowest: compounds 4, 3 and 2 (each within the scatter of the next, the first and the last beyond it); then compound 1.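

In this assay the exchange of benzyloxy for 4-bromophenyl on a carbonyl carbon gives a 1.6-fold lower number from compound 3 to compound 4 (0.20 log units; within the scatter) and so leaves the read-out within the usual scatter of repeated measurements. Among the compounds shown here, the earlier step showed only that one aryl group can be exchanged for another at this kind of place with a change beyond the scatter; this pair shows that a benzyloxycarbonyl group and a (4-bromophenyl)carbonyl group can stand on the same amino nitrogen with no real difference in the number, even though the oxygen of benzyloxy and its one hydrogen-bond acceptor are gone. No measurement shown here gives a reason for this result.

What a carboxylic acid, an amine or a plain alkyl chain would do on this carbonyl carbon remains open, as every group shown there carries a six-membered aromatic ring of carbon only. The compounds shown also offer no single-place pair that tests benzyloxy against an aryl group on the core of compound 1, so whether the same exchange behaves alike on that core is unknown.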